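The source may hold more compounds than are shown below. What is called first, only, known or untested is meant among the compounds shown, and "the series" means these compounds.

Measured so far:
compound 1, `CN(C)C(=O)CN1CCC(c2cc3c(-c4ccc(=O)n(C5CCOCC5)c4)ccnc3[nH]2)CC1`, 840000 nM
compound 2, `CC(=O)N1CCC(c2cc3c(-c4ccc(=O)n(C(C)C)c4)ccnc3[nH]2)CC1`, 27000 nM
compound 3, `COc1cc(C(=O)N2CCCC2)ccc1-c1ccnc2[nH]c(C3CCNCC3)cc12`, 590000 nM

In a physicochemical assay for solubility, in phosphate buffer, at pH 7.4 (a higher number here means a more soluble compound, a lower number a less soluble compound), compound 2 gives the lowest of the three numbers; the nearest, compound 3, stands at a gap that lies beyond the scatter, and compound 1 lies further still. Compound 4, `CC(C)n1cc(-c2ccnc3[nH]c(C4CCN(Cc5cccs5)CC4)cc23)ccc1=O`, is compound 2 with one change: (thiophen-2-yl)methyl in place of acetyl on an amine nitrogen in a ring. Within the data shown here, no measured pair here shows this exact change, so the step has to be judged from the values alone. A rise seems likely, since without an acetyl on that amine nitrogen compound 1 gives 840000 nM and compound 3 gives 590000 nM. The step from compound 2 to compound 4 in this assay is expected to be upward and beyond the scatter, a 3.7-fold higher number from compound 2 to compound 4 (0.57 log units; beyond the scatter). Compound 4 is therefore estimated at 100000 nM in this assay, with a likely range from 20000 nM to 500000 nM.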

Compound 4, solubility: 25000 nM
Estimate against measurement, compound 4: 4.0-fold (0.60 log units) above, within the range that was stated.
By their numbers in this assay, from the lowest: compounds 4 and 2 (each within the scatter of the next); then compounds 3 and 1 (each within the scatter of the next).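

In this assay, this is the only step shown that changes the group on the amine nitrogen in a ring while the rest of the molecule stays the same. Replacing acetyl with (thiophen-2-yl)methyl gives a 1.1-fold lower number from compound 2 to compound 4 (0.03 log units; within the scatter), so a larger group containing an aromatic ring and no carbonyl leaves the read-out unchanged within the scatter in this pair. Nothing measured here explains this result. On these data alone, it remains open whether a carboxymethyl group or a simple methyl at that nitrogen, with the rest of compound 2 kept, would move the value beyond the scatter.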